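Acid to isopentyl amide: what the cells may tolerate

This account rests on a few compounds, and the source may have more. Where it says the series, first, only, none or still open, it means among the compounds named here.

The study follows three compounds on a shared core. Compound 1 `COc1ccc(Cn2c(C(=O)NC(C)c3ccccc3)cc3sccc32)cc1` and compound 2 `COc1ccc(Cn2c(C(=O)N3CCC(C(=O)O)CC3)cc3sccc32)cc1` have been measured in an ADME assay on HEK-293T cells (Homo sapiens) for cytotoxicity, read by luminescence, with a stated time of 24 h; a lower number here means that less compound is tolerated, a higher number that more compound is tolerated. For compound 1 the result is a limit of the assay, > 100000 nM. For compound 2 the result is likewise a limit of the assay, > 100000 nM. The step that the two limits leave unreadable from compound 1 to compound 2 therefore cannot be sized, since both values sit at the limit of > 100000 nM in this assay, at which 2 of the 2 values shown sit. Compound 3 `COc1ccc(Cn2c(C(=O)N3CCC(C(=O)NCCC(C)C)CC3)cc3sccc32)cc1` has not yet been measured in this assay. It differs from compound 2 in one place: isopentylamino in place of hydroxy on a carbonyl carbon. For the measured compounds named here, the only measured step that could bear on this change is the unreadable one between the two earlier compounds, so it offers no guide to the direction or size of the change from carboxy to isopentylcarbamoyl. With both measured compounds standing at the limit of > 100000 nM in this assay, at which 2 of the 2 values shown sit, compound 3 is expected to stand near that limit as well, so the step of a number no higher from compound 2 to compound 3 (the limit leaves the size open) is estimated to lie within the usual scatter. Compound 3 is thus expected to give about 100000 nM, with a range from 30000 nM to 300000 nM.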

Compound 3, half-maximal cytotoxic concentration: 30900 nM
Compound 3: the middle estimate sits 3.2-fold (0.51 log units) above what was measured; the range from low to high includes it.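

For the compounds shown here, at this carbonyl carbon, on the saturated ring carbon, the change from carboxy to isopentylcarbamoyl gives the first readable step in this assay: isopentylamino in place of hydroxy produces an at least 3.2-fold lower number from compound 2 to compound 3 (0.51 log units; beyond the scatter), so less of compound 3 is tolerated by the cells. The step between compound 1 and compound 2 cannot be read, and it gave no sign that a change in this part of the molecule could register in this assay at all, whereas the new step shows that one can. Compound 3 is also the only one of the three whose result is a number rather than a limit of the assay: the limit of > 100000 nM in this assay, at which 2 of the 3 values shown sit.

From the compounds shown here alone, compound 2 stands only at a limit, so how far the true step extends beyond the printed size stays open. The compounds shown also leave open whether the isopentyl chain or the amide link goes with the lower number, a question that a primary amide, a methylamino group or a longer chain such as octylamino on the same carbonyl carbon could help to separate.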